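The compounds below may be only part of what the source reports. "The series", "measured", "known", "first", "only" and "open" are said of these compounds alone.

In a functional assay on trachea (Rattus norvegicus, strain Wistar), with a stated time of 15 min (on this read-out higher numbers stand for an effect only at larger amounts of compound and lower numbers for an effect already at smaller amounts), compound 1 (`CC(NC(=O)NS(=O)(=O)c1ccc(Cl)cc1)c1cc(Br)ccc1OCc1ccccc1`) gives 30800 nM and compound 2 (`Cc1ccc(OCc2ccccc2)c(C(C)NC(=O)NS(=O)(=O)c2ccc(Cl)cc2)c1`) gives 30400 nM. Compound 3 (`COc1ccc(Cl)cc1C(C)NC(=O)N(C)S(=O)(=O)c1ccccc1`) gives 1700 nM, the lowest of the three numbers and beyond the scatter from both of the others. Compound 4 (`COc1ccc(Br)cc1C(C)NC(=O)N(C)S(=O)(=O)c1ccccc1`) has not yet been measured. It departs from compound 3 by a single exchange, bromo in place of chloro on an aromatic carbon, para to a methoxy group.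

Within the data shown here, only one measured step bears on this change, and it does so indirectly. That step is a 1.0-fold lower number from compound 1 to compound 2 (0.01 log units; within the scatter), in which methyl takes the place of bromo on an aromatic carbon and the number stays within the scatter. No exchange of chloro for bromo has been measured, and that pair is built differently from compound 3, so the evidence is thin. Among the measured compounds shown here, still, the one substituent exchange on hand moved nothing, and so no shift beyond the scatter is expected here. The expected size of the change is no change at the digits printed from compound 3 to compound 4 (within the scatter), with no firm direction. For compound 4 the estimated value is 1700 nM, with an expected range from 750 nM to 3800 nM.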

Compound 4, half-maximal effective concentration: 8400 nM
For compound 4 the middle estimate is 4.9-fold (0.69 log units) below the measured one, and the stated range ends below it.
By their numbers in this assay, from the lowest: compound 3; then compound 4; then compounds 2 and 1 (each within the scatter of the next).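

In this assay, bromo in place of chloro gives a 4.9-fold higher number from compound 3 to compound 4 (0.69 log units; beyond the scatter), which shows that this aromatic carbon, para to a methoxy group, responds to a change of one heavy atom for another, and that the direction of the step is towards a higher number, with an effect only at larger amounts of compound. Among these compounds, the earlier compounds could not show this: their single exchange, methyl in place of bromo, gave a 1.0-fold lower number from compound 1 to compound 2 (0.01 log units; within the scatter), on a differently built core, so a silent exchange there turns out to say little about this place in compound 3. The exchange leaves the counted features unchanged, with no ring, donor, acceptor or net charge entering or leaving, and nothing among the data shown accounts for the shift.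

The compounds shown leave open how this carbon would respond to fluoro, a nitrile, an amine or a plain hydrogen, so two halogens give only a single step and no trend. They also leave open whether chloro and bromo would differ in the same way on the core of compound 1.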